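Benzyl ether in place of ethyl on a naphthol core

This account rests on a few compounds, and the source may have more. Where it says the series, first, only, none or still open, it means among the compounds named here.

Measured compounds:
Compound 1 `Cc1ccc(Cc2ccc3ccccc3c2O)cc1`: 24 nM
Compound 2 `COc1ccc(Cc2ccc3ccccc3c2O)cc1`: 75 nM
Compound 3 `CCOc1ccc(Cc2ccc3ccccc3c2O)cc1`: 62 nM

All three share one core and differ only in the group on the outer benzene ring. In an assay on RBL-1 cells with Polyunsaturated fatty acid 5-lipoxygenase (Rattus norvegicus) as the target (a higher number here means a weaker inhibitor, a lower number a stronger inhibitor), compound 3 gives 62 nM, the second highest of the three numbers; one step to it lies within the scatter (a 1.2-fold lower number from compound 2 to compound 3 (0.08 log units; within the scatter)) and the other lies beyond it (a 2.6-fold higher number from compound 1 to compound 3 (0.41 log units; beyond the scatter)). Compound 4 `Oc1c(Cc2ccc(OCc3ccccc3)cc2)ccc2ccccc12` grows out of compound 3 by phenyl in place of methyl on a saturated chain carbon bound to an oxygen on an aromatic ring. For the measured compounds named here, the only measured step at this place is the one from methoxy to ethoxy, a 1.2-fold lower number from compound 2 to compound 3 (0.08 log units; within the scatter), which stayed within the scatter. The two steps from methyl to an alkoxy group, a 3.1-fold higher number from compound 1 to compound 2 (0.49 log units; beyond the scatter) and a 2.6-fold higher number from compound 1 to compound 3 (0.41 log units; beyond the scatter), were modest. Going by the values given here, no measured step shows a ring added at this chain carbon, so the direction is uncertain. The step expected here is a 1.0-fold lower number from compound 3 to compound 4 (0.01 log units; within the scatter). Compound 4 is therefore estimated at 60 nM in this assay, with a range from 15 nM to 250 nM.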

Compound 4, half-maximal inhibitory concentration: 72 nM
For compound 4 the middle estimate is 1.2-fold (0.08 log units) below the measured one, and the stated range covers the measured number.
By their numbers in this assay, from the lowest: compound 1; then compounds 3, 4 and 2 (each within the scatter of the next).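

Replacing the methyl end of the ethoxy group with a phenyl ring adds a six-membered aromatic ring, yet the number in this assay stays within the scatter (a 1.2-fold higher number from compound 3 to compound 4 (0.06 log units; within the scatter)). The comparison with the methoxy group reads the same way (a 1.0-fold lower number from compound 2 to compound 4 (0.02 log units; within the scatter)), so this position accepts methoxy, ethoxy and benzyloxy without a difference that can be told apart, while benzyloxy, like the two smaller alkoxy groups, remains weaker than methyl on the aromatic carbon (a 3.0-fold higher number from compound 1 to compound 4 (0.48 log units; beyond the scatter)). No measurement at hand accounts for this flat result.

From the compounds shown here alone, how an amine or a carboxylic acid on the added phenyl ring would read stays open. Also open, going by these compounds, is whether ethyl or a longer carbon chain in place of the methyl of compound 1 would keep its advantage.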